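Exchanging the quinoline for a pyridine in compound 3

The compounds below may be only part of what the source reports. "The series", "measured", "known", "first", "only" and "open" are said of these compounds alone.

Of the compounds shown here, two sharing a common lactone core have been measured. Compound 1 `CCCC(CCC)C(=O)OCC1(CO)C/C(=C/c2ccncc2)C(=O)O1` carries a pyridin-4-yl group and a dipropylacetate ester, and in an assay on cells for displacement of a labelled ligand from Ras guanyl-releasing protein 3 (Homo sapiens) (a lower number here means a stronger inhibitor, a higher number a weaker inhibitor), compound 1 gives 44 nM. Compound 2 `CN(C)c1ccc(C(=O)OCC2(CO)C/C(=C/c3ccc4ccccc4n3)C(=O)O2)cc1` carries a quinolin-2-yl group and a dimethylaminobenzoate ester, and in this assay compound 2 gives 2040 nM. Compound 2 therefore holds the higher of the two numbers, and its gap to compound 1 lies well beyond the usual scatter. Since the two compounds differ in two places, the data do not show which of the two changes accounts for the gap.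

Compound 3 `CN(C)c1ccc(C(=O)OCC2(CO)C/C(=C/c3ccncc3)C(=O)O2)cc1` keeps the ester of compound 2 and differs from it in one place: pyridin-4-yl in place of quinolin-2-yl on a double-bonded chain carbon bound to a double-bonded ring carbon. Within the data shown here, no measured pair isolates this change, so its effect is uncertain. Because compound 1, which also carries pyridin-4-yl, gives 44 nM, a move toward a lower number is expected, and the step from compound 2 to compound 3 is estimated at a 10-fold lower number from compound 2 to compound 3 (1.01 log units; beyond the scatter). Compound 3 is therefore expected to give about 200 nM in this assay, with a range from 40 nM to 1000 nM.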

Compound 3, inhibition constant in the Ras guanyl-releasing protein 3 assay: 2360 nM
Estimate against measurement, compound 3: 12-fold (1.07 log units) below; measured number above the stated range.
By their numbers in the Ras guanyl-releasing protein 3 assay, from the lowest: compound 1; then compounds 2 and 3 (each within the scatter of the next).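

With the 4-(dimethylamino)phenyl ester held fixed, replacing quinolin-2-yl with pyridin-4-yl on a double-bonded chain carbon bound to a double-bonded ring carbon gives, in the Ras guanyl-releasing protein 3 assay, a 1.2-fold higher number from compound 2 to compound 3 (0.06 log units; within the scatter), so with this ester the removal of the carbon-only aromatic ring leaves the result unchanged within the scatter. The large gap between the first two compounds can now be placed at the other site, since exchanging 1-propylbutyl for 4-(dimethylamino)phenyl on a carbonyl carbon, with pyridin-4-yl kept, gives a 54-fold higher number from compound 1 to compound 3 (1.73 log units; beyond the scatter). In a physicochemical assay for lipophilicity (a lower number here means a more polar compound, a higher number a more lipophilic compound), compound 2 gives 3.22 and compound 3 gives 2.07. For the pair differing at the chain carbon, the absence of any change beyond the scatter in the Ras guanyl-releasing protein 3 assay comes with a clear fall in lipophilicity in the physicochemical assay: the measured partition coefficient of compound 2, 3.22, and of compound 3, 2.07, a number 1.15 log units lower (beyond the scatter)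

On these data alone, whether quinolin-2-yl and pyridin-4-yl would also stay level with 1-propylbutyl on the carbonyl carbon remains open, as the flat result rests on a single pair carrying the 4-(dimethylamino)phenyl ester. Also open, as far as these compounds go, is what a plain phenyl or a longer alkyl chain on that carbonyl carbon would give, and so which part of the 4-(dimethylamino)phenyl group goes with the large step.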